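Compound 3 to compound 4: bromo for fluoro

A few compounds are considered here, and "the series" means these few. Any claim that something is new, unique, unknown or untested is made for them only; others in the source may bear on it.

In a functional assay on HepG2 cells (Homo sapiens) for cytotoxicity, read by MTT assay, with a stated time of 24 h (a higher number here means a weaker inhibitor, a lower number a stronger inhibitor), compound 1 `CN1C/C(=C\c2ccncc2)C(=O)/C(=C/c2ccccc2F)C1` gives 4600 nM, compound 2 `Cc1ccc(S(=O)(=O)N2C/C(=C\c3ccncc3)C(=O)/C(=C/c3ccccc3F)C2)cc1` gives 9700 nM, and compound 3 `O=C1/C(=C/c2ccncc2)CN(S(=O)(=O)c2ccc(F)cc2)C/C1=C\c1ccccc1F` gives 20300 nM, the highest number of the three. Compound 4 `O=C1/C(=C/c2ccncc2)CN(S(=O)(=O)c2ccc(Br)cc2)C/C1=C\c1ccccc1F` has not yet been measured and differs from compound 3 by bromo in place of fluoro on an aromatic carbon. The closest evidence comes from the same place on the ring: a 2.1-fold higher number from compound 2 to compound 3 (0.32 log units; beyond the scatter), with fluoro in place of methyl. The steps of a 2.1-fold higher number from compound 1 to compound 2 (0.32 log units; beyond the scatter) and a 4.4-fold higher number from compound 1 to compound 3 (0.64 log units; beyond the scatter) concern the sulfonyl groups that stand in place of methyl on the ring nitrogen. Among the measured compounds shown here, no bromo compound has been measured, so only a small move back toward the value of compound 2 is expected. The expected change is a 1.7-fold lower number from compound 3 to compound 4 (0.23 log units; within the scatter). Compound 4 is estimated at 12000 nM, with an expected range of 5500 nM to 26000 nM.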

Compound 4, half-maximal inhibitory concentration: 9300 nM
Estimate against measurement, compound 4: 1.3-fold (0.11 log units) above, and the stated range covers the measured number.
By their numbers in this assay, from the lowest: compound 1; then compounds 4 and 2 (each within the scatter of the next); then compound 3.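

At this aromatic carbon, para to a large group, bromo undoes the rise seen with fluoro (a 2.2-fold lower number from compound 3 to compound 4 (0.34 log units; beyond the scatter)). Bromo and methyl here cannot be told apart (a 1.0-fold lower number from compound 2 to compound 4 (0.02 log units; within the scatter)), and the (4-bromophenyl)sulfonyl group in place of methyl on the ring nitrogen gives only a modest step (a 2.0-fold higher number from compound 1 to compound 4 (0.31 log units; beyond the scatter)), so among these three groups fluoro alone stands apart. Nothing available bears on why these groups differ.

From the compounds shown here alone, whether chloro, methoxy or nitrile at this carbon would track bromo or fluoro remains open. So does the effect of an amine there.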